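The source may hold more compounds than are shown below. What is called first, only, known or untested is meant among the compounds shown, and "the series" means these compounds.

Three compounds of a shared core have been taken through an ADME assay on microsomes from liver (Homo sapiens) for metabolic stability, read by LC-MS, with a stated time of 10 min; on this read-out lower numbers stand for a less stable compound and higher numbers for a more stable compound. Compound 1, `CCCN(C[C@H]1Cc2c(cccc2N2CCNCC2)CN1)[C@H]1CCCc2cccnc21`, gives 100% in this assay. Within the data shown here, compound 2, `CN(C[C@H]1Cc2c(cccc2N2CCN(c3cccc(C(F)(F)F)c3)CC2)CN1)[C@H]1CCCc2cccnc21`, gives 90.3%, a number that lies within the usual scatter of the one for compound 1. Compound 3, `CN(C[C@H]1Cc2c(cccc2N2CCN(c3ccccn3)CC2)CN1)[C@H]1CCCc2cccnc21`, gives 27.4%, well apart from both. Among the measured compounds shown here, the only single-point step among the measured compounds is a number 62.9 percentage points lower from compound 2 to compound 3 (beyond the scatter), and it sits on the amine nitrogen in the ring, not on the chain that carries the propyl group.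

Compound 4, `CCN(C[C@H]1Cc2c(cccc2N2CCNCC2)CN1)[C@H]1CCCc2cccnc21`, has not yet been measured in this assay. It differs from compound 1 by hydrogen in place of methyl on a saturated chain carbon, two bonds along the chain from an amine nitrogen. For the measured compounds named here, no measured step touches this part of the molecule, so nothing in the data argues for a change beyond the scatter, and a step of about a number 7 percentage points lower from compound 1 to compound 4 (within the scatter) is therefore expected. Compound 4 is estimated to give 93% in this assay, within a range from 78% to 100%.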

Compound 4, percent of the compound remaining: 79.1%
For compound 4 the middle estimate is 13.9 percentage points above the measured one; low and high end bracket the measured number.
By their numbers in this assay, from the lowest: compound 3; then compound 4; then compounds 2 and 1 (each within the scatter of the next).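

In this assay, the change from propyl to ethyl gives a number 20.9 percentage points lower from compound 1 to compound 4 (beyond the scatter), the first step measured at this part of the molecule. Among these compounds, the chain on the amine nitrogen therefore counts in this read-out: losing a single methyl here moves the number beyond the scatter, whereas the only step seen before lay on the amine nitrogen in the ring. Nothing in the data shown speaks to the cause of this step.

The compounds shown leave open whether a butyl chain or a cyclopropylmethyl group at this place would follow the same direction, as a single step sets no trend. From the compounds shown here alone, it also remains open whether the step would hold with pyridin-2-yl or 3-(trifluoromethyl)phenyl on the amine nitrogen in the ring.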